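Methyl Substitution on a Chromone Series Against SW480 Cells

The source may report more compounds than this note shows. Statements on the series, on what has been measured and on what is new or still open speak of the compounds shown alone.

Compound 1: `O=c1cc(CSc2nc3ccccc3s2)oc2ccccc12` — > 25000 nM
Compound 2: `Cc1nnc(SCc2cc(=O)c3ccccc3o2)s1` — > 25000 nM
Compound 3: `Cc1ccc2oc(CSc3nc4ccccc4s3)cc(=O)c2c1` — > 25000 nM

Of the compounds shown here, three have been tested in a functional assay on SW480 cells (Homo sapiens) for cytotoxicity, read by MTT assay, with a stated time of 72 h; on this read-out lower numbers stand for stronger inhibition and higher numbers for weaker inhibition. Compound 1 reaches only the limit of the assay, > 25000 nM. Compound 2 likewise gives only a limit, > 25000 nM. Compound 3 also stops at a limit, > 25000 nM. Compounds 1 and 3 differ in one place, (methyl in place of hydrogen on an aromatic carbon). Because all three values sit at the limit of > 25000 nM in this assay, at which 3 of the 3 values shown sit, the step that the two limits leave unreadable from compound 1 to compound 3 cannot be read. The difference between the core of compound 1 and the core of compound 2 is not broken down here.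

Compound 4, `Cc1ccc2oc(CSc3nnc(C)s3)cc(=O)c2c1`, has not yet been measured in this assay. It differs from compound 2 in the same way, (methyl in place of hydrogen on an aromatic carbon), with the place of the change described in the same words as for compound 3. Since compound 1 gives > 25000 nM and compound 3 gives > 25000 nM, both limits, no direction for this change can be drawn. Compound 4 is therefore expected to remain at the limit, an estimated step that the limit leaves unreadable from compound 2 to compound 4, giving an estimate of 40000 nM (range 15000 nM to 120000 nM).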

Compound 4, half-maximal inhibitory concentration: > 25000 nM
Compound 4: only a limit was reported; the forecaster's own chance of this, stated with the estimate: 85%; the middle value does not contradict the limit.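

In this assay compound 4 gives only a limit, > 25000 nM. For the compounds shown here, compound 2 also gives only a limit, so no step between compound 2 and compound 4 can be read, because all the values sit at the same limit: the limit of > 25000 nM in this assay, at which 4 of the 4 values shown sit. The compounds shown leave open whether methyl in place of hydrogen on an aromatic carbon changes cytotoxicity at all.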